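Dichlorophenyl in place of indole at the thiazolidine carbon

The compounds below may be only part of what the source reports. "The series", "measured", "known", "first", "only" and "open" are said of these compounds alone.

Measured so far in a functional assay on RH7777 cells (Homo sapiens) for antiproliferative activity against RH7777 (Rattus norvegicus), read by sulforhodamine B assay; on this read-out higher numbers stand for weaker inhibition and lower numbers for stronger inhibition:
Compound 1 `CCCCCCCCCCCCCCCCCCNC(=O)[C@H]1CSC(c2c[nH]c3ccccc23)N1` sits at a limit of this assay, > 20000 nM.
Compound 2 `CCCCCCCCCCCCCCCCCCNC(=O)[C@H]1CSC(c2cccnc2)N1` gives 10500 nM.
Compound 3 `CCCCCCCCCCCCCCCCCCNC(=O)[C@H]1CSC(c2cccc(O)c2)N1` gives 31000 nM.

Compound 1 stands only at a limit in this assay, (the limit of > 20000 nM in this assay, at which 1 of the 3 values shown sits), so no number is known for it; it is among the weakest inhibitors shown, but how weak is not readable. The step under discussion leads to compound 4 `CCCCCCCCCCCCCCCCCCNC(=O)[C@H]1CSC(c2c(Cl)cccc2Cl)N1` through (2,6-dichlorophenyl in place of 1H-indol-3-yl on a saturated ring carbon).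

Two measured steps start from compound 1. The first, an at least 1.9-fold lower number from compound 1 to compound 2 (0.27 log units; that floor lies within the scatter), gives only a floor that lies within the scatter. The second, a step that the limit leaves unreadable from compound 1 to compound 3, cannot be read at all. Between the two measured replacements themselves, a 3.0-fold higher number from compound 2 to compound 3 (0.47 log units; beyond the scatter) shows that exchanging the group on this saturated ring carbon moves the number only modestly. All three measured compounds sit in the weak range, and nothing among them points to a large gain from a further change at this carbon.

Compound 4 is therefore expected to remain a weak inhibitor, with an estimated step of an at least 1.3-fold lower number from compound 1 to compound 4 (0.12 log units; that floor lies within the scatter). The value of compound 4 in this assay is estimated at 15000 nM, within a range from 5000 nM to 40000 nM.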

Compound 4, half-maximal inhibitory concentration: > 20000 nM
Compound 4 gave a limit, no number; the forecaster's own chance of this, stated with the estimate: 35%; middle value at least 1.3-fold (0.12 log units) away from the limit.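

In this assay compound 4 stands at a limit and not at a number, which makes 2,6-dichlorophenyl the second group on this saturated ring carbon, after the 1H-indol-3-yl of compound 1, to end there: the limit of > 20000 nM in this assay, at which 2 of the 4 values shown sit. Measured against the pyridin-3-yl group, the change gives an at least 1.9-fold higher number from compound 2 to compound 4 (0.27 log units; that floor lies within the scatter), so this replacement cannot be told apart from the usual scatter of the assay. The steps that link compound 4 to compound 1 and to compound 3 cannot be read, and the one step among these compounds that is readable and beyond the scatter remains a 3.0-fold higher number from compound 2 to compound 3 (0.47 log units; beyond the scatter).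

On these data alone, what numbers compound 1 and compound 4 would have stays open, and so does whether any group on this carbon can move the value by much. The compounds shown also leave open what a phenyl group bearing an amine or a carboxylic acid would do at this carbon, and what a shorter chain on the amide would do with the 2,6-dichlorophenyl group kept in place.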